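Adding a Phenyl to a Weak Nicotinic Receptor Ligand

The source may hold more compounds than are shown below. What is called first, only, known or untested is meant among the compounds shown, and "the series" means these compounds.

Compound 1 `CO[C@H]1CC[C@H]2CCN(C)[C@H]2C1`: in an assay on HEK293 cells for displacement of a labelled ligand from Neuronal acetylcholine receptor; alpha4/beta4 (Rattus norvegicus), with a stated time of 4 h (on this read-out lower numbers stand for stronger inhibition and higher numbers for weaker inhibition), compound 1 gives > 300000 nM, which is a limit of the assay and not a number.
Compound 2 `COCCO[C@H]1CC[C@H]2CCN(C)[C@H]2C1`: in this assay compound 2 gives > 300000 nM, again a limit rather than a number.
Compound 3 `CO[C@H]1CC=C2CCN(C)[C@H]2C1`: in this assay compound 3 gives 100000 nM.

Among the compounds with values here, compound 3 therefore stands as the only compound of the three with an actual number; the other two sit at a limit of the assay. Within the data shown here, the one step between measured compounds that differ in a single place, a step that the two limits leave unreadable from compound 1 to compound 2, cannot be sized, because both of its ends rest at the limit of > 300000 nM in this assay, at which 2 of the 3 values shown sit. That step swaps a methoxymethyl for a hydrogen on the same kind of carbon, and it tells nothing about size or direction.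

Compound 4 `CN1CCC2=CC[C@H](OCc3ccccc3)C[C@@H]21` has not been measured. It differs from compound 3 by phenyl in place of hydrogen on a saturated chain carbon bound to an oxygen on a saturated carbon. Among the measured compounds shown here, no measured step involves a phenyl group, so the expectation for compound 4 rests on the value of compound 3 alone and carries wide uncertainty. The step from compound 3 to compound 4 is expected to be a 3.3-fold lower number from compound 3 to compound 4 (0.52 log units; beyond the scatter), a modest gain at best. For compound 4 the estimate in this assay is 30000 nM, with a plausible range from 5000 nM to 300000 nM.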

Compound 4, inhibition constant: 300000 nM
Estimate against measurement, compound 4: 10-fold (1.00 log units) below, within the range that was stated.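

Phenyl in place of hydrogen on a saturated chain carbon bound to an oxygen on a saturated carbon gives a 3.0-fold higher number from compound 3 to compound 4 (0.48 log units; beyond the scatter) in this assay. Within the data shown here, a higher number on this read-out stands for weaker inhibition, so this is the first readable sign that enlarging the group at this place can weaken the compound, although the change is modest. The earlier change at this kind of carbon gave no such sign, since the step from compound 1 to compound 2 cannot be read with both of its ends resting at limits: the limit of > 300000 nM in this assay, at which 2 of the 4 values shown sit.

Among these compounds, with only this one readable step, it remains open whether the loss is specific to phenyl or would come with other groups at this place on the core of compound 3. An amine, a carboxylic acid or a longer chain at the same carbon could move the number in either direction, and the same phenyl change on the core of compound 1 could behave differently from the step seen here.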